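Swapping Benzimidazole for Benzoxazole on a Sulfonamide Scaffold

A few compounds are considered here, and "the series" means these few. Any claim that something is new, unique, unknown or untested is made for them only; others in the source may bear on it.

Measured so far:
compound 1, `O=S(=O)(Nc1cc(-c2ccc3nc[nH]c3c2)cnc1Cl)c1ccc(F)cc1`: > 12000 nM, a limit
compound 2, `Nc1cn2cc(-c3cnc(Cl)c(NS(=O)(=O)c4ccc(F)cc4)c3)ccc2n1`: > 12000 nM, a limit

In an assay on U-87MG ATCC cells for inhibition of RAC-alpha serine/threonine-protein kinase (Homo sapiens), read by AlphaScreen, with a stated time of 2 h (on this read-out lower numbers stand for stronger inhibition and higher numbers for weaker inhibition), compound 1 gives > 12000 nM, which is a limit of the assay rather than a measured number. Compound 2 gives > 12000 nM in this assay, again a limit. Compound 1 thus stands at the limit of > 12000 nM in this assay, at which 2 of the 2 values shown sit, so neither reading says how weak the inhibition really is, only that it lies past what the assay resolves. Going by the values given here, no two measured compounds differ in a single place, so there is no measured step to lean on.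

Compound 3, `O=S(=O)(Nc1cc(-c2ccc3ncoc3c2)cnc1Cl)c1ccc(F)cc1`, is the compound still to be tested. It differs from compound 1 by 1,3-benzoxazol-6-yl in place of 1H-benzimidazol-6-yl on an aromatic carbon. Because compound 1 sits at > 12000 nM, itself a limit, this change is expected to leave the reading in this assay where it is, with no step beyond the usual scatter and most likely another limit. Compound 3 is therefore expected to give about 15000 nM in this assay, with a plausible range from 5000 nM to 50000 nM. The expected step from compound 1 to compound 3 is a step that the limit leaves unreadable from compound 1 to compound 3, meaning essentially none.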

Compound 3, half-maximal inhibitory concentration: > 12000 nM
Compound 3 was reported as a limit; the forecaster's own chance of this, stated with the estimate: 80%; the middle value does not contradict the limit.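

In this assay, going by these compounds alone, compound 1 and compound 3 are both reported only as limits, so swapping 1H-benzimidazol-6-yl for 1,3-benzoxazol-6-yl gives no step that can be read: the limit of > 12000 nM in this assay, at which 3 of the 3 values shown sit. The compounds shown leave open how weak each one really is, and which change to the shared core would bring a reading within the range of the assay.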